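Hydroxy in place of propoxy on a shared benzimidazole-free core

The source may report more compounds than this note shows. Statements on the series, on what has been measured and on what is new or still open speak of the compounds shown alone.

Compound 2 `CCCOc1ccc(-c2nc3cc(C(F)(F)F)ccc3[nH]2)cc1` stands with the lowest of the two numbers measured in a functional assay on aorta (Rattus norvegicus, strain Wistar) for inhibition, with a stated time of 60 min (a lower number here means that less compound is needed, a higher number that more compound is needed for the effect), giving 524000 nM; its nearest neighbour is compound 1 `CN(C)c1ccc(-c2nc3cc(C(F)(F)F)ccc3[nH]2)cc1`, which in this assay gives 550000 nM, a difference within the scatter. Going by the values given here, the one measured step, a 1.0-fold lower number from compound 1 to compound 2 (0.02 log units; within the scatter), therefore shows no change beyond the scatter for an exchange on the same aromatic carbon.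

Compound 3 `Oc1ccc(-c2nc3cc(C(F)(F)F)ccc3[nH]2)cc1` is the unmeasured member. It differs from compound 2 by hydrogen in place of propyl on an oxygen on an aromatic ring. Among the compounds with values here, no measured pair shows this exact exchange; the only step available, from compound 1 to compound 2, concerns a different group at the same place and was flat. On that basis, compound 3 is expected to give a number close to that of compound 2 in this assay, with the step of a 1.0-fold higher number from compound 2 to compound 3 (0.02 log units; within the scatter) estimated to lie within the scatter. The estimate for compound 3 is 550000 nM, with a range from 200000 nM to 1500000 nM, until the measurement shows otherwise.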

Compound 3, half-maximal effective concentration: 219000 nM
The estimate for compound 3 lay 2.5-fold (0.40 log units) above the measured number; low and high end bracket the measured number.
By their numbers in this assay, from the lowest: compound 3; then compounds 2 and 1 (each within the scatter of the next).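

Going by these compounds alone, removing the propyl from the oxygen is the first change at this place that registers in this assay, giving a 2.4-fold lower number from compound 2 to compound 3 (0.38 log units; beyond the scatter) as a modest step that lies beyond the scatter. The same holds against the dimethylamino group, where hydroxy in its place on the aromatic carbon gives a 2.5-fold lower number from compound 1 to compound 3 (0.40 log units; beyond the scatter), so this position, which looked flat when propoxy and dimethylamino were exchanged, does respond once the oxygen carries a hydrogen instead of a chain. No measured information at hand accounts for this difference.

The three compounds cannot say whether the step depends on the hydrogen on the oxygen itself or simply on the loss of the propyl chain, and a methoxy or ethoxy group at this place would bear on that question, as would a primary amine set against the dimethylamino group. They also leave open how far the trend runs with other replacements on this aromatic carbon, such as a carboxylic acid, and whether it holds when the trifluoromethyl group on the shared core is exchanged.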